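The compounds below may be only part of what the source reports. "The series", "measured", "known", "first", "only" and "open" are said of these compounds alone.

Measured so far:
compound 1 `OCCOCn1cnc2c(O)ncnc21`: in a functional assay on L1210 cells (Mus musculus) for inhibition (on this read-out lower numbers stand for stronger inhibition and higher numbers for weaker inhibition), compound 1 gives > 1000 ug/mL, a limit of the assay.
compound 2 `CC(=O)OCCOCn1cnc2c(Cl)nc(N)nc21`: in this assay compound 2 gives > 1000 ug/mL, also a limit.
compound 3 `Cc1nc2c(O)nc(N)nc2n1COCCO`: in this assay compound 3 gives > 500 ug/mL, again a limit.

Compound 3 thus stands at a limit only, and so do the other two values shown: they fall at the limit of > 1000 ug/mL in this assay, at which 2 of the 3 values shown sit, and at the limit of > 500 ug/mL in this assay, at which 1 of the 3 values shown sits. Among the measured compounds shown here, no numeric step between measured compounds is available. Compound 4 `Nc1nc(O)c2nc(N3CCCCC3)n(COCCO)c2n1` differs from compound 3 by piperidin-1-yl in place of methyl on an aromatic carbon. With every value a limit, no direction can be read from the series; in this assay the expectation is no step beyond the scatter, with compound 4 most likely again reported as a limit. Compound 4 is estimated at 500 ug/mL in this assay, with a range from 100 ug/mL to 1000 ug/mL. The expected step is a number no higher from compound 3 to compound 4 (the limit leaves the size open).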

Compound 4, concentration for 50% inhibition: > 500 ug/mL
Compound 4 gave a limit, no number; the forecaster's own chance of this, stated with the estimate: 70%; the middle value lies on the limit itself.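

In this assay compound 3 and compound 4 are both reported only as limits, and no step can be read from compound 3 to compound 4. The compounds shown leave open whether piperidin-1-yl in place of methyl changes inhibition at all.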